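Cytotoxicity limits across a shared-core hydroxy/methoxy pair

A few compounds are considered here, and "the series" means these few. Any claim that something is new, unique, unknown or untested is made for them only; others in the source may bear on it.

Measured compounds:
compound 1, `CCCc1c(Cl)c(O)cc(O)c1Oc1c(Cl)c(O)c(Cl)c2c1C(=O)O[C@@H]2CC`
compound 2, `CCCc1c(Cl)c(OC)cc(O)c1Oc1c(Cl)c(O)c(Cl)c2c1C(=O)O[C@@H]2CC`
compound 3, `CCCc1cc(O)cc(O)c1Oc1c(Cl)c(O)c(Cl)c2c1C(=O)O[C@@H]2CC`

All three were read in an ADME assay on MDCK cells (Canis lupus familiaris) for cytotoxicity, read by CellTiter-Glo, with a stated time of 40 h; on this read-out lower numbers stand for higher toxicity in this test and higher numbers for lower toxicity in this test. In this assay compound 1 gives > 50000 nM, which is a limit of the assay and not a number. Compound 2 gives > 50000 nM, likewise a limit. Compound 3 gives > 100000 nM, again only a limit. Compound 2 differs from compound 1 by methyl in place of hydrogen on an oxygen on an aromatic ring; the step that the two limits leave unreadable from compound 1 to compound 2 cannot be sized, as both values rest at the limit of > 50000 nM in this assay, at which 2 of the 3 values shown sit. Compound 3 differs from compound 1 by hydrogen in place of chloro on an aromatic carbon, and the step that the two limits leave unreadable from compound 1 to compound 3 is equally unreadable, lying between the limit of > 50000 nM in this assay, at which 2 of the 3 values shown sit, and (the limit of > 100000 nM in this assay, at which 1 of the 3 values shown sits). No ordering among compounds 1, 2 and 3 can be drawn from these values.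

Compound 4, `CCCc1cc(O)cc(OC)c1Oc1c(Cl)c(O)c(Cl)c2c1C(=O)O[C@@H]2CC`, has not been measured in this assay. It differs from compound 3 by methyl in place of hydrogen on an oxygen on an aromatic ring, the same change as from compound 1 to compound 2, at the same place. For compound 4 the step of a number no higher from compound 3 to compound 4 (the limit leaves the size open) is expected to be small, resting on compound 1 and compound 2 both sitting at the limit of > 50000 nM in this assay, at which 2 of the 3 values shown sit. Compound 4 is therefore estimated at 100000 nM, most likely returned again as a limit, within 50000 nM to 200000 nM.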

Compound 4, half-maximal cytotoxic concentration: > 100000 nM
Compound 4: no number, only a limit (the forecaster's own chance of this, stated with the estimate: 85%); the middle value lies on the limit itself.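

In this assay compound 3 gives > 100000 nM, a limit and not a number. Compound 4 gives > 100000 nM, likewise a limit, so no step can be read between compound 3 and compound 4. The compounds shown leave open where the half-maximal cytotoxic concentration of any of these compounds actually lies, and whether hydroxy to methoxy changes it.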